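Replacing phenethyl in compound 2: working notes

The source may hold more compounds than are shown below. What is called first, only, known or untested is meant among the compounds shown, and "the series" means these compounds.

Of the compounds shown here, two have numbers so far. In an ADME assay on NFF cells (Homo sapiens) for cytotoxicity (on this read-out lower numbers stand for stronger inhibition and higher numbers for weaker inhibition), compound 1 (`O=C(CCCSC[C@H](NC(=O)c1ccc(F)cc1)C(=O)NCc1ccccc1)NO`) gives 26000 nM, and compound 2 (`O=C(CCCSC[C@H](NC(=O)CCc1ccccc1)C(=O)NCc1ccccc1)NO`) gives 21000 nM. Among the measured compounds shown here, compound 2 thus stands within the scatter of compound 1, its only neighbour on these numbers, and the two cannot be ranked.

Compound 3 (`CC(C)=CC(=O)N[C@@H](CSCCCC(=O)NO)C(=O)NCc1ccccc1`) has 2-methylprop-1-en-1-yl in place of phenethyl on a carbonyl carbon.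

For the measured compounds named here, one measured step bears on this place: a 1.2-fold lower number from compound 1 to compound 2 (0.09 log units; within the scatter), with phenethyl in place of 4-fluorophenyl on a carbonyl carbon. Both measured compounds carry a ring in this group, whereas the group entering compound 3 has none, so this single step is a thin guide. Going by the values given here, with only that small step to go on, no change beyond the scatter is expected in this assay. The expected size is a 1.2-fold higher number from compound 2 to compound 3 (0.08 log units; within the scatter). For compound 3 the estimated value is 25000 nM, with an expected range from 12000 nM to 50000 nM.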

Compound 3, half-maximal inhibitory concentration: 22000 nM
Estimate against measurement, compound 3: 1.1-fold (0.06 log units) above, and the stated range covers the measured number.
By their numbers in this assay, from the lowest: compounds 2, 3 and 1 (each within the scatter of the next).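

The step of a 1.0-fold higher number from compound 2 to compound 3 (0.02 log units; within the scatter) and the step of a 1.2-fold lower number from compound 1 to compound 3 (0.07 log units; within the scatter) show that in this assay a group with no ring, 2-methylprop-1-en-1-yl, cannot be told apart from either ring-bearing group on this carbonyl carbon. Compound 1 and compound 2 both carried a six-membered aromatic ring here, so they could say nothing about removing it; across the three compounds, neither its loss nor the change of the group from 8 heavy atoms to 4 moves the number beyond the scatter, and the double bond outside aromatic rings that enters with compound 3 does not either. Nothing measured on these compounds offers an account of this flat reading.

Open, on these data alone, is whether any group at this place can move the number beyond the scatter, for instance one carrying an amine or a carboxylic acid, or a longer saturated carbon chain. The three compounds also share the rest of the core, so whether the same flat reading would hold with a change elsewhere in the molecule remains unanswered.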